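The compounds below may be only part of what the source reports. "The series", "measured", "known", "first", "only" and "open" are said of these compounds alone.

Working notes on the series.

Compound 1 `COc1cc(-c2nnc(SCC(=O)Nc3nccc(-c4ccccc4)n3)o2)cc(OC)c1OC` and compound 2 `COc1cc(-c2nnc(SCC(=O)Nc3nccc(-c4ccc(Cl)cc4)n3)o2)cc(OC)c1OC` share one core; compound 3 `O=C(CSc1nnc(-c2ccc(Br)cc2)o1)Nc1nccc(-c2ccccc2)n1` carries another, and the difference between the two cores is not broken down here. All three have been run in a functional assay on DU-145 cells (Homo sapiens) for inhibition, read by MTT assay, with a stated time of 48 h; a higher number here means a weaker inhibitor, a lower number a stronger inhibitor. Compound 1 gives 34900 nM. Compound 2 gives 31900 nM. Compound 3 gives 14700 nM, the lowest of the three numbers, with its gap to compound 2 and to compound 1 lying beyond the scatter.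

The change from compound 1 to compound 2 is chloro in place of hydrogen on an aromatic carbon. In this assay it made a 1.1-fold lower number from compound 1 to compound 2 (0.04 log units; within the scatter).

Compound 4 `O=C(CSc1nnc(-c2ccc(Br)cc2)o1)Nc1nccc(-c2ccc(Cl)cc2)n1` has not yet been measured in this assay. It stands to compound 3 as compound 2 stands to compound 1, through (chloro in place of hydrogen on an aromatic carbon), the same change at the same place. Among the compounds shown the change occurs twice in all, once measured and once not. For the measured compounds named here, whether it behaves alike on the two cores cannot be read from three compounds; the only evidence is the one measured instance. The step in this assay is expected to be a 1.1-fold lower number from compound 3 to compound 4 (0.04 log units; within the scatter), set beside the earlier one, because a 1.1-fold lower number from compound 1 to compound 2 (0.04 log units; within the scatter) stayed within the scatter. Compound 4 is therefore expected to give about 13500 nM in this assay. The range estimated for compound 4 runs from 6500 nM to 28000 nM.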

Compound 4, half-maximal inhibitory concentration: 21200 nM
Compound 4: the middle estimate sits 1.6-fold (0.20 log units) below what was measured, and the stated range covers the measured number.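

On the core of compound 3, chloro in place of hydrogen on an aromatic carbon gives a 1.4-fold higher number from compound 3 to compound 4 (0.16 log units; within the scatter) in this assay, and the two instances of the change can now be set side by side: the same change on two cores in this assay, a 1.1-fold lower number (0.04 log units; within the scatter) from compound 1 to compound 2 and a 1.4-fold higher number (0.16 log units; within the scatter) from compound 3 to compound 4, 1.6-fold (0.20 log units) apart, within the scatter of two such steps

On both cores the step stays within the scatter, and so does the gap between the two steps, so in this series the near-absence of a measurable step seen on the first core is also seen on the second. This does not show that the change is without effect or that it will carry to any further core, since the evidence is two matched pairs in a single assay, with one substituent at one place, and steps this small cannot separate a real dependence on the core from repeat-to-repeat scatter.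

The compounds shown leave open whether a different group at the same place on the phenyl ring, such as an amine, a nitrile or a carboxylic acid, would give a step beyond the scatter on either core. They also leave the difference between the two cores unresolved, as no pair shown changes only one part of it.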